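The compounds below may be only part of what the source reports. "The series", "measured", "known", "first", "only" and "open" are said of these compounds alone.

Measured so far in a functional assay for inhibition, tested at 100 uM; on this read-out higher numbers stand for more inhibition at the one concentration tested (going by the name of the read-out) and lower numbers for less inhibition:
compound 1, `O=S(=O)(/C=C/S(=O)(=O)c1ccc(Cl)cc1)CC1=NCCO1`: 85.5%
compound 2, `O=S(=O)(CC1=NCCO1)c1c[nH]cc1S(=O)(=O)c1ccc(Cl)cc1`: 92.1%
compound 3, `O=S(=O)(/C=C/S(=O)(=O)c1ccccc1)CC1=NCCO1`: 82.1%

Compound 3 differs from compound 1 by hydrogen in place of chloro on an aromatic carbon; the resulting step is a number 3.4 percentage points lower from compound 1 to compound 3 (within the scatter). Compound 2 shares the chloro-bearing ring with compound 1 but carries a different core; the difference between the two cores is not broken down here. Compound 4, `O=S(=O)(CC1=NCCO1)c1c[nH]cc1S(=O)(=O)c1ccccc1`, is not yet measured. It differs from compound 2 by hydrogen in place of chloro on an aromatic carbon, the same change as from compound 1 to compound 3, at a place described in the same words. Because the earlier step of a number 3.4 percentage points lower from compound 1 to compound 3 (within the scatter) lay within the scatter, the step in this assay is expected to be of the same order, a number 3.1 percentage points lower from compound 2 to compound 4 (within the scatter). Compound 4 is therefore estimated at 89%, with a range from 80% to 96%. This rests on one prior pair only.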

Compound 4, a percentage reported as inhibition, at one concentration (the size of the read-out at that concentration, not a potency): 87.7%
Compound 4: middle estimate off by 1.3 percentage points, on the high side, and the stated range covers the measured number.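

In this assay, hydrogen in place of chloro gives a number 4.4 percentage points lower from compound 2 to compound 4 (within the scatter). Set beside the earlier step, the change reads alike on both cores: the same change on two cores in this assay, a number 3.4 percentage points lower (within the scatter) from compound 1 to compound 3 and a number 4.4 percentage points lower (within the scatter) from compound 2 to compound 4, 1 percentage points apart, within the scatter of two such steps

This shows that, on these two cores, the 4-chlorophenyl to phenyl change gives steps that stay within the scatter and do not differ from each other; it does not show that chloro has any real effect on the read-out, or that the same would hold on a third core or at another concentration.

The compounds shown leave open whether a different group at this place on the ring, such as an amine, a carboxylic acid or a longer chain, would give a step beyond the scatter.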